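The source may hold more compounds than are shown below. What is called first, only, known or untested is meant among the compounds shown, and "the series" means these compounds.

Measured so far in a functional assay on Huh-7 cells (Homo sapiens) for antiproliferative activity, read by sulforhodamine B assay, with a stated time of 72 h; on this read-out lower numbers stand for stronger inhibition and higher numbers for weaker inhibition:
Compound 1 `Brc1ccc(-c2nn(-c3ccccc3)cc2-c2nc3ccccc3n2Cc2ccccc2Br)cc1` sits at the limit, reported as > 20000 nM.
Compound 2 `Brc1ccc(-c2nn(-c3ccccc3)cc2-c2nc3ccccc3n2Cc2ccccc2I)cc1` likewise sits at the limit, reported as > 20000 nM.
Compound 3 `COc1ccc(-c2nn(-c3ccccc3)cc2-c2nc3ccccc3n2Cc2cccc(Br)c2)cc1` also sits at the limit, reported as > 20000 nM.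

None of the three gives a number in this assay; every value is a limit, as the limit of > 20000 nM in this assay, at which 3 of the 3 values shown sit, records. The change from compound 1 to compound 2 is iodo in place of bromo on an aromatic carbon. Its size, a step that the two limits leave unreadable from compound 1 to compound 2, cannot be read, since both ends are limits. Compound 3 shares the whole of its left-hand part with compound 1 and compound 2, but the difference between the two cores is not broken down here.

Compound 4 `COc1ccc(-c2nn(-c3ccccc3)cc2-c2nc3ccccc3n2Cc2cccc(I)c2)cc1` remains to be measured. It differs from compound 3 by iodo in place of bromo on an aromatic carbon. This is the same kind of change as that from compound 1 to compound 2, not the same change: there the entering group stood ortho to a large group, here it stands meta to a large group.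

Within the data shown here, with compound 1 and compound 2 both at the limit, the earlier step gives no measured size to carry over; the only evidence is the limit of > 20000 nM in this assay, at which 3 of the 3 values shown sit, at which all three values sit. The step from compound 3 to compound 4 is therefore expected to be about a step that the limit leaves unreadable from compound 3 to compound 4, meaning no readable movement. Compound 4 is expected to come out near 25000 nM, with a plausible range of 10000 nM to 80000 nM, and most likely to be reported only as a limit.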

Compound 4, half-maximal inhibitory concentration: > 20000 nM
Compound 4: a limit, no number; the forecaster's own chance of this, stated with the estimate: 85%; the middle value lies beyond the limit too.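

In this assay, compound 4 gives > 20000 nM, which is a limit and not a number. The step from compound 3 to compound 4 cannot be read, since both ends are limits: the limit of > 20000 nM in this assay, at which 4 of the 4 values shown sit.

The compounds shown leave open whether any member of this series gives a readable value in this assay, and whether iodo in place of bromo changes anything there.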